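A Halogenated Aryl Variant of a Bile Acid Receptor Ligand

The source may hold more compounds than are shown below. What is called first, only, known or untested is meant among the compounds shown, and "the series" means these compounds.

Compound 1 `COC(=O)/C=C/c1cccc(N(Cc2ccc(-c3ccc(C)cc3)cc2)C(=O)C(C)C)c1` is the more potent of the two measured compounds in an assay on isolated protein with Bile acid receptor (Homo sapiens) as the target (on this read-out higher numbers stand for an effect only at larger amounts of compound and lower numbers for an effect already at smaller amounts), where compound 1 gives 118 nM. Compound 2 `COC(=O)/C=C/c1cccc(N(Cc2ccc(-c3ccc(C)cc3)cc2)C(=O)NC(C)C)c1` differs from compound 1 only at the carbonyl carbon, and in this assay compound 2 gives 449 nM; that change is a 3.8-fold higher number from compound 1 to compound 2 (0.58 log units; beyond the scatter). Compound 3 `COC(=O)/C=C/c1cccc(N(Cc2ccc(-c3ccc(F)c(Cl)c3)cc2)C(=O)C(C)C)c1` is not yet measured; it differs from compound 1 in one place: 3-chloro-4-fluorophenyl in place of 4-methylphenyl on an aromatic carbon. Within the data shown here, no measured step touches that part of the molecule, so the one known step, a 3.8-fold higher number from compound 1 to compound 2 (0.58 log units; beyond the scatter), bears on it only as a gauge of how far a single change has moved this read-out here. Without a matching precedent, compound 3 is expected to stay close to compound 1, with an expected step of a 1.3-fold higher number from compound 1 to compound 3 (0.10 log units; within the scatter) that may well fall within the scatter. Compound 3 is therefore estimated at 150 nM, with a range from 50 nM to 450 nM.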

Compound 3, half-maximal effective concentration: 129 nM
Estimate against measurement, compound 3: 1.2-fold (0.07 log units) above; measured number inside the range.
By their numbers in this assay, from the lowest: compounds 1 and 3 (each within the scatter of the next); then compound 2.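

In this assay the exchange of 4-methylphenyl for 3-chloro-4-fluorophenyl gives a 1.1-fold higher number from compound 1 to compound 3 (0.04 log units; within the scatter) and so cannot be told apart from repeated measurement: this aromatic carbon, para to a large group, takes a ring carrying fluorine and chlorine in place of the one carrying methyl with no discernible change in the read-out. The earlier change at the carbonyl carbon, a 3.8-fold higher number from compound 1 to compound 2 (0.58 log units; beyond the scatter) and thus beyond the scatter, shows that this read-out can respond to a single change, whereas this exchange of groups does not move it. No evidence at hand bears on this result.

The compounds shown leave open whether fluorine or chlorine alone on this ring would give the same picture. They also leave open how a carboxylic acid in place of the methyl ester, or an amine on this ring, would move the number.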